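This account rests on a few compounds, and the source may have more. Where it says the series, first, only, none or still open, it means among the compounds named here.

In a functional assay on HepG2 cells (Homo sapiens) for inhibition, read by MTT assay, with a stated time of 48 h (on this read-out higher numbers stand for weaker inhibition and lower numbers for stronger inhibition), compound 1 `COc1cc(/C=N/Nc2nc(-c3cccc(Br)c3)cs2)cc(Br)c1OC` gives 66200 nM. Compound 2 `COc1ccccc1-c1csc(N/N=C/c2cc(OC)c(OC)c(Br)c2Br)n1` is reported as > 100000 nM, a limit and not a number, so it stands at the limit of > 100000 nM in this assay, at which 1 of the 2 values shown sits. Compound 3 `COc1ccccc1-c1csc(N/N=C/c2cc(Br)c(OC)c(OC)c2)n1` has not yet been measured. It has hydrogen in place of bromo on an aromatic carbon of compound 2, at the place ortho to a bromo group and para to a methoxy group (hydrogen in place of bromo on an aromatic carbon). Going by the values given here, no measured pair shows this change alone. Compound 3 shares the resulting substituted aromatic ring with compound 1, which gives 66200 nM, and this is the basis for expecting a move toward stronger inhibition in this assay. The estimated change is an at least 1.5-fold lower number from compound 2 to compound 3 (0.18 log units; that floor lies within the scatter), a modest one. For compound 3 the expected value is 65000 nM, within an estimated range of 28000 nM to 100000 nM.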

Compound 3, half-maximal inhibitory concentration: 82100 nM
Compound 3: middle estimate off by 1.3-fold (0.10 log units), on the low side, and the stated range covers the measured number.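

In this assay, replacing the bromo group with hydrogen at this position, ortho to a bromo group and para to a methoxy group, gives an at least 1.2-fold lower number from compound 2 to compound 3 (0.08 log units; that floor lies within the scatter), so this change has only a floor, and that floor does not establish a real effect. Going by these compounds alone, the value for compound 2 is a limit and not a number: the limit of > 100000 nM in this assay, at which 1 of the 3 values shown sits. With hydrogen at this position, 2-methoxyphenyl in place of 3-bromophenyl gives a 1.2-fold higher number from compound 1 to compound 3 (0.09 log units; within the scatter), so the first direct comparison of these two aromatic groups does not tell them apart in this assay.

As far as these compounds go, how far compound 2 lies past its limit remains open, and with it the true size of the step from bromo to hydrogen. Also open, from the compounds shown here alone, is what an amine, a carboxylic acid or a longer chain would give at this position.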